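A chloro substituent on the aryl ring of a chalcone-like acetate

The source may hold more compounds than are shown below. What is called first, only, known or untested is meant among the compounds shown, and "the series" means these compounds.

Of the compounds shown here, three have been measured in a functional assay on HBL-100 cells (Homo sapiens) for inhibition, read by sulforhodamine B assay, with a stated time of 48 h; a lower number here means a stronger inhibitor of growth, a higher number a weaker inhibitor of growth. Compound 1 `O=C(/C(=C/c1ccc(Cl)cc1)CCl)c1ccccc1` gives 3200 nM. Compound 2 `CC(=O)OC/C(=C\C1CCCCC1)C(=O)c1ccccc1` gives 21000 nM, and compound 3 `CC(=O)OC/C(=C\c1ccccc1)C(=O)c1ccccc1` gives 17000 nM. Within this set, compound 3 stands second highest of the three numbers; the nearest is compound 2, and the step of a 1.2-fold lower number from compound 2 to compound 3 (0.09 log units; within the scatter) is within the scatter, while the furthest is compound 1, whose number lies well below that of compound 3.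

The new compound 4 `CC(=O)OC/C(=C\c1ccc(Cl)cc1)C(=O)c1ccccc1` differs from compound 3 in one place: chloro in place of hydrogen on an aromatic carbon. Among the compounds with values here, no measured step in this set tests exactly this change on its own. Within the data shown here, the only measured step, from compound 2 to compound 3, concerns a different position and is within the scatter, so it says little here. Compound 1 also carries the chloro group, but it differs from compound 3 in a second place as well, so its lower number cannot be attributed to the chloro alone.

Without a directly comparable step, the expectation for compound 4 in this assay is a step of modest size, if any, with the direction uncertain, a 1.4-fold lower number from compound 3 to compound 4 (0.15 log units; within the scatter). Compound 4 is therefore estimated at 12000 nM, with a range from 4000 nM to 30000 nM.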

Compound 4, concentration for 50% growth inhibition: 2300 nM
Beside the measured number, compound 4's estimate is 5.2-fold (0.72 log units) above it; measured number below the stated range.
By their numbers in this assay, from the lowest: compounds 4 and 1 (each within the scatter of the next); then compounds 3 and 2 (each within the scatter of the next).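

In this assay, the chloro on this aromatic carbon, para to a large group, brings a clear change in growth inhibition (a 7.4-fold lower number from compound 3 to compound 4 (0.87 log units; beyond the scatter)), and the change from the cyclohexyl group to the 4-chlorophenyl group is similar in size (a 9.1-fold lower number from compound 2 to compound 4 (0.96 log units; beyond the scatter)), whereas the plain phenyl group alone gave no such change (a 1.2-fold lower number from compound 2 to compound 3 (0.09 log units; within the scatter)). Once the ring carries chloro, acetoxy and chloro on the saturated chain carbon cannot be told apart (a 1.4-fold lower number from compound 1 to compound 4 (0.14 log units; within the scatter)), so the low number of compound 1 no longer points to its chain chloro. Nothing measured here explains why the ring chloro has this effect.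

The compounds shown leave open whether a fluoro, methoxy or nitrile group on the same aromatic carbon would match chloro. They also leave open how a hydroxy group or an amine on the saturated chain carbon would compare with acetoxy.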